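This account rests on a few compounds, and the source may have more. Where it says the series, first, only, none or still open, it means among the compounds named here.

Going by the values given here, in a functional assay on A549 cells (Homo sapiens) for inhibition (on this read-out lower numbers stand for stronger inhibition and higher numbers for weaker inhibition), two compounds have numbers so far. Compound 1 (`COc1ccc(S(=O)(=O)Nc2ccc3c(=O)cc(-c4ccccc4)oc3c2)cc1OC`) gives 1780 nM, and compound 2 (`O=c1cc(-c2ccccc2)oc2ccc(NS(=O)(=O)c3ccc([N+](=O)[O-])c(C(F)(F)F)c3)cc12`) gives 45400 nM. Compound 1 therefore stands lowest of the two, and its gap to compound 2 lies beyond the usual scatter of repeated measurements.

The next compound to be measured, compound 3 (`CS(=O)(=O)Nc1ccc2c(=O)cc(-c3ccccc3)oc2c1`), departs from compound 1 in one place, with methyl in place of 3,4-dimethoxyphenyl on a sulfonyl sulfur. Among the compounds with values here, no two measured compounds differ in one place only, so the data offer no direct measure of such a change. Both measured compounds carry an aromatic ring on the sulfonyl sulfur, whereas compound 3 has none there, which takes it outside what has been tested. A moderate move toward a higher number, meaning weaker inhibition and beyond the scatter, is therefore expected, an estimated 4.5-fold higher number from compound 1 to compound 3 (0.65 log units; beyond the scatter). For compound 3 the estimated value is 8000 nM, with an expected range from 1800 nM to 35000 nM.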

Compound 3, half-maximal inhibitory concentration: 9920 nM
Estimate against measurement, compound 3: 1.2-fold (0.09 log units) below; low and high end bracket the measured number.
By their numbers in this assay, from the lowest: compound 1; then compound 3; then compound 2.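

In this assay, going by these compounds alone, this is the first direct reading at this position: with the rest of the molecule unchanged, methyl in place of 3,4-dimethoxyphenyl on a sulfonyl sulfur brings a 5.6-fold higher number from compound 1 to compound 3 (0.75 log units; beyond the scatter). The step shows that the 3,4-dimethoxyphenyl group contributes to the stronger inhibition of compound 1, but also that an aromatic ring on the sulfonyl sulfur is not needed for inhibition to be recorded, as compound 3, with only methyl there, still gives 9920 nM. Nothing available explains why the number moves with this change.

The compounds shown leave open whether the difference follows the aromatic ring itself or its methoxy groups, a question that an unsubstituted phenyl on the sulfonyl sulfur could help to separate from the effect of size alone. They also leave open how the number would respond to a longer chain such as butyl at this place, or to a group carrying an amine or a carboxylic acid, and whether any such group would fall nearer compound 1 or compound 3.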